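From hydroxy to amino in compound 2

This account rests on a few compounds, and the source may have more. Where it says the series, first, only, none or still open, it means among the compounds named here.

Within the data shown here, in a physicochemical assay for lipophilicity, read by HPLC (a lower number here means a more polar compound, a higher number a more lipophilic compound), compound 2 `Cc1ccsc1C(=CCCN(C)C(CCO)C(=O)NCc1ccc(F)cc1)c1sccc1C` gives 5.87, the lowest of the three numbers measured so far. Compound 1 `Cc1ccsc1C(=CCCN(C)C(CCO)C(=O)NCc1ccc(F)cc1F)c1sccc1C` gives 6.37, and compound 3 `Cc1ccsc1C(=CCCN(C)C(CCO)C(=O)NCc1ccccc1Cl)c1sccc1C` gives 6.23. These two lie within the scatter of each other.

Compound 4 `Cc1ccsc1C(=CCCN(C)C(CCN)C(=O)NCc1ccc(F)cc1)c1sccc1C` has not been measured. It differs from compound 2 at a single site: amino in place of hydroxy on a saturated chain carbon, three bonds along the chain from an amine nitrogen and a carbonyl carbon. That is amino in place of hydroxy on a saturated chain carbon, three bonds along the chain from an amine nitrogen and a carbonyl carbon.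

Among the measured compounds shown here, no measured step touches this site. The three known steps change halogens on the aromatic group instead: a number 0.50 log units lower from compound 1 to compound 2 (beyond the scatter), a number 0.14 log units lower from compound 1 to compound 3 (within the scatter) and a number 0.36 log units higher from compound 2 to compound 3 (beyond the scatter). They offer only a guide to size, and the largest of them is modest.

For the measured compounds named here, the expected change is a number 0.47 log units lower from compound 2 to compound 4 (beyond the scatter), a modest step whose direction no measured pair confirms. For compound 4 the estimated value is 5.4, with an expected range from 4.7 to 6.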

Compound 4, partition coefficient: 6.45
Compound 4: middle estimate off by 1.05 log units, on the low side; the measured number lies above the stated range.
By their numbers in this assay, from the lowest: compound 2; then compounds 3, 1 and 4 (each within the scatter of the next).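

Placing amino where hydroxy stood on this saturated chain carbon gives, in this assay, a number 0.58 log units higher from compound 2 to compound 4 (beyond the scatter) and so shows that this chain site can shift the reading. The two groups match in heavy-atom count, hydrogen-bond donors, hydrogen-bond acceptors and net charge, so those counts alone do not predict the change seen in this pair. Among these compounds, the shift is also similar in size to the halogen change in a number 0.50 log units lower from compound 1 to compound 2 (beyond the scatter) on the aromatic group, so the earlier compounds' aromatic changes are not the only ones that register here.

No measurement shown explains the direction of this step. This single pair leaves open whether the rise carries over to the aromatic groups of compound 1 and compound 3, and how a methoxy group, a carboxylic acid or a longer chain would read at this site.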